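The source may hold more compounds than are shown below. What is called first, only, known or untested is meant among the compounds shown, and "the series" means these compounds.

Measured in a functional assay on HCT-116 cells (Homo sapiens) for antiproliferative activity, read by MTT assay, with a stated time of 48 h; on this read-out lower numbers stand for stronger inhibition and higher numbers for weaker inhibition:
compound 1 `COc1ccc(-c2cc3c(cn2)[nH]c(=O)n3-c2cc(OC)c(OC)c(OC)c2)cc1O`: 340 nM
compound 2 `CCOc1ccc(-c2cc3c(cn2)[nH]c(=O)n3-c2cc(OC)c(OC)c(OC)c2)cc1`: 6660 nM
compound 3 `COc1ccc(-c2cc3c(cn2)[nH]c(=O)n3-c2cc(OC)c(OC)c(OC)c2)cc1C`: 1810 nM

Among these three, compound 3 holds the second highest number, with compound 1 lower and compound 2 higher. The next analogue, compound 4 `COc1ccc(-c2cc3c(cn2)[nH]c(=O)n3-c2cc(OC)c(OC)c(OC)c2)cc1C(=O)O`, differs from compound 3 in one group: carboxy in place of methyl on an aromatic carbon, ortho to a methoxy group. Among the compounds with values here, the most relevant measured change is a 5.3-fold higher number from compound 1 to compound 3 (0.73 log units; beyond the scatter), the only one that swaps a group on this same carbon, and it shows that the read-out responds to a change there. The change of a 20-fold higher number from compound 1 to compound 2 (1.29 log units; beyond the scatter) is larger, and a 3.7-fold lower number from compound 2 to compound 3 (0.57 log units; beyond the scatter) is modest, but both alter the ring more widely. Within the data shown here, no measured compound carries a carboxy, so the direction remains uncertain. A modest step towards a higher number is tentatively expected, namely a 2.2-fold higher number from compound 3 to compound 4 (0.34 log units; beyond the scatter). For compound 4 the estimated value is 4000 nM, with an expected range from 1200 nM to 15000 nM.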

Compound 4, half-maximal inhibitory concentration: 3070 nM
Compound 4: middle estimate off by 1.3-fold (0.11 log units), on the high side, and the stated range covers the measured number.
By their numbers in this assay, from the lowest: compound 1; then compounds 3 and 4 (each within the scatter of the next); then compound 2.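

In this assay, carboxy in place of methyl on this aromatic carbon, ortho to a methoxy group, gives a step within the scatter, a 1.7-fold higher number from compound 3 to compound 4 (0.23 log units; within the scatter), so this assay does not tell the two groups apart, even though carboxy brings a hydrogen-bond donor and acceptor that methyl lacks. Hydroxy on the same carbon now stands apart from both groups, with a 9.0-fold higher number from compound 1 to compound 4 (0.96 log units; beyond the scatter) alongside the earlier methyl step, while the 3-carboxy-4-methoxyphenyl compound remains separated from the 4-ethoxyphenyl compound by a 2.2-fold lower number from compound 2 to compound 4 (0.34 log units; beyond the scatter). Nothing measured here explains this pattern. The compounds shown leave open whether an amine, a primary amide or a methyl ester on this carbon would group with hydroxy or with methyl and carboxy.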